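A few compounds are considered here, and "the series" means these few. Any claim that something is new, unique, unknown or untested is made for them only; others in the source may bear on it.

Working notes on the ester series.

For the measured compounds named here, compound 1 `CCCOC(=O)/C=C(C)/C=C/CC(C)CCCC(C)C` gives 7.28 in a physicochemical assay for lipophilicity (on this read-out higher numbers stand for higher lipophilicity and lower numbers for lower lipophilicity), and stands highest of the three numbers so far. Going by the values given here, compound 2 `CCCOC(=O)/C=C(C)/C=C/CC(C)CCCC(C)(C)OC` gives 6.08 in this assay, and the one change between the two, methoxy in place of hydrogen on a saturated chain carbon bound to three saturated chain carbons, produces a number 1.20 log units lower from compound 1 to compound 2 (beyond the scatter). Compound 3 `CCOC(=O)/C=C(C)/C=C/CC(C)CCC1OC1(C)C` gives 4.76 in this assay, the lowest of the three; it differs from compound 1 in more than one place, so the two values show only that the gap is wide.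

Compound 4 `CC(/C=C/CC(C)CCCC(C)C)=C\C(=O)CC(C)C` is not yet measured. It differs from compound 1 as isobutyl in place of propoxy on a carbonyl carbon. Among the compounds with values here, no measured step changes the carbonyl substituent, so neither step above bears directly on it; the one measured step shows that adding an oxygen to the chain lowers the number by a large amount. Replacing propoxy by isobutyl removes an oxygen, so for compound 4 a rise beyond the scatter is expected, a number 0.62 log units higher from compound 1 to compound 4 (beyond the scatter). Compound 4 is therefore estimated at 7.9, in the range 7.4 to 8.4.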

Compound 4, partition coefficient: 7.22
Estimate against measurement, compound 4: 0.68 log units above; measured number outside the range, below it.
By their numbers in this assay, from the lowest: compound 3; then compound 2; then compounds 4 and 1 (each within the scatter of the next).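

In this assay, for the compounds shown here, isobutyl in place of propoxy on a carbonyl carbon gives a number 0.06 log units lower from compound 1 to compound 4 (within the scatter) and is the first step read at this position. Propoxy and isobutyl both count 4 heavy atoms, and exchanging the oxygen-bearing group for the all-carbon one does not carry the number beyond the scatter, so the large step on the chain, a number 1.20 log units lower from compound 1 to compound 2 (beyond the scatter), does not carry over to this change. No measured evidence bears on why this position behaves this way.

The compounds shown leave open how other groups on this carbonyl carbon, such as an amine, a carboxylic acid or a longer chain, would read. Also open, going by these compounds, is whether isobutyl in place of propoxy gives the same step on the methoxy-bearing chain of compound 2.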